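Anilide substituent swap: phenyl to chloro

The source may report more compounds than this note shows. Statements on the series, on what has been measured and on what is new or still open speak of the compounds shown alone.

Among the compounds with values here, compound 2 `O=C(CCCCCCNC(=O)C(O)(O)C(F)(F)F)Nc1ccc(-c2ccccc2)cc1` gives 38000 nM in an assay on isolated protein for inhibition of protein deacetylase HDAC6 (Homo sapiens), read by chemiluminescence, with a stated time of 3 h (on this read-out lower numbers stand for stronger inhibition and higher numbers for weaker inhibition), the lower of the two numbers measured so far; compound 1 `O=C(CCCCCCNC(=O)C(O)(O)C(F)(F)F)Nc1ccc(Br)cc1` gives 100000 nM in this assay. The change to compound 3 `O=C(CCCCCCNC(=O)C(O)(O)C(F)(F)F)Nc1ccc(Cl)cc1` is chloro in place of phenyl on an aromatic carbon. Within the data shown here, the one measured step that bears on it runs the other way: a 2.6-fold lower number from compound 1 to compound 2 (0.42 log units; beyond the scatter), where bromo gave way to phenyl. Chloro, like bromo, is a halogen, so removing phenyl is expected to undo most of that gain and raise the number, a 2.4-fold higher number from compound 2 to compound 3 (0.37 log units; beyond the scatter). Compound 3 is estimated at 90000 nM with a range of 35000 nM to 250000 nM.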

Compound 3, half-maximal inhibitory concentration: 260000 nM
For compound 3 the middle estimate is 2.9-fold (0.46 log units) below the measured one, outside the stated range (above it).
By their numbers in this assay, from the lowest: compound 2; then compound 1; then compound 3.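

With a 6.8-fold higher number from compound 2 to compound 3 (0.84 log units; beyond the scatter) as the step, phenyl counts for more against chloro than it does against bromo at this position. With a 2.6-fold higher number from compound 1 to compound 3 (0.41 log units; beyond the scatter) as the second step, the two halogens also separate beyond the scatter, so a halogen here cannot be treated as a single interchangeable choice; across these three compounds the numbers rise from phenyl to bromo to chloro. No available evidence explains this order.

Open, as far as these compounds go, is whether fluoro or iodo would follow the same halogen order. Also open, from the compounds shown here alone, is whether an amine, a carboxylic acid or a benzyl group at this place would bring the number below that of compound 2.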